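A few compounds are considered here, and "the series" means these few. Any claim that something is new, unique, unknown or untested is made for them only; others in the source may bear on it.

Measured compounds:
compound 1 `COc1cccc(C(=O)Nc2cccc(-c3oc4cc(-c5ccc(F)cc5)ccc4c(=O)c3O)c2)c1`: 18900 nM
compound 2 `O=C(Nc1cccc(-c2oc3cc(-c4ccc(F)cc4)ccc3c(=O)c2O)c1)c1cccc(F)c1`: 6590 nM

Among the compounds with values here, in a functional assay on HCC1937 cells (Homo sapiens) for antiproliferative activity, read by CCK-8 assay, with a stated time of 72 h (on this read-out lower numbers stand for stronger inhibition and higher numbers for weaker inhibition), the lowest of the two numbers belongs to compound 2; the single measured step, a 2.9-fold lower number from compound 1 to compound 2 (0.46 log units; beyond the scatter), lies beyond the scatter and is modest. Compound 3 `N#Cc1ccc(C(=O)Nc2cccc(-c3oc4cc(-c5ccc(F)cc5)ccc4c(=O)c3O)c2)cc1` is not yet measured and differs from compound 2 as 4-cyanophenyl in place of 3-fluorophenyl on a carbonyl carbon. Within the data shown here, that measured step also reworked the substituent on this same benzoyl ring, so it is the only guide here. A step of similar, modest size is therefore expected, a 1.2-fold higher number from compound 2 to compound 3 (0.08 log units; within the scatter), with its direction uncertain. Compound 3 is estimated at 8000 nM, within 2500 nM to 25000 nM.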

Compound 3, half-maximal inhibitory concentration: 2990 nM
Beside the measured number, compound 3's estimate is 2.7-fold (0.43 log units) above it; the measured number falls inside the stated range.
By their numbers in this assay, from the lowest: compound 3; then compound 2; then compound 1.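

In this assay, the aryl group on the carbonyl carbon still shifts the number: 4-cyanophenyl in place of 3-fluorophenyl gives a 2.2-fold lower number from compound 2 to compound 3 (0.34 log units; beyond the scatter), and in place of 3-methoxyphenyl gives a 6.3-fold lower number from compound 1 to compound 3 (0.80 log units; beyond the scatter). Both steps change the group and its ring position at once, so the nitrile and its placement cannot be told apart. Nothing available explains this order. From the compounds shown here alone, whether 3-cyanophenyl or 4-fluorophenyl would separate the two stays open. So does the outcome with an amine or a carboxylic acid on this ring.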